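A few compounds are considered here, and "the series" means these few. Any claim that something is new, unique, unknown or untested is made for them only; others in the source may bear on it.

Measured so far in an ADME assay on L929 cells (Mus musculus) for cytotoxicity, read by resazurin assay, with a stated time of 72 h; a lower number here means a stronger inhibitor, a higher number a weaker inhibitor:
Compound 1, `O=C(/C=C/c1ccc2c(c1)B(O)OC2)c1ccccc1O`: compound 1 gives > 10 ug/mL, a limit of the assay and not a number.
Compound 2, `Nc1ccc(C(=O)/C=C/c2ccc3c(c2)B(O)OC3)cc1`: compound 2 gives > 10 ug/mL, likewise a limit of the assay.

Compound 2 therefore stands at the limit of this assay, with no number of its own. The step that the two limits leave unreadable from compound 1 to compound 2 cannot be read, since both ends are limits; the change there was 4-aminophenyl in place of 2-hydroxyphenyl on a carbonyl carbon. Among the compounds with values here, the only evidence on that step is the limit of > 10 ug/mL in this assay, at which 2 of the 2 values shown sit.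

Compound 3, `O=C(/C=C/c1ccc2c(c1)B(O)OC2)c1cccs1`, is still to be measured in this assay. It differs from compound 2 as follows: thiophen-2-yl in place of 4-aminophenyl on a carbonyl carbon. Within the data shown here, the one measured step that touches the same place, the carbonyl carbon, is the unreadable step from compound 1 to compound 2, so no size or direction can be taken from the measurements for this assay. With both measured compounds at the limit, compound 3 is expected to sit at the limit as well, and the step that the limit leaves unreadable from compound 2 to compound 3 is expected to lie within the scatter. Compound 3 is estimated at 20 ug/mL, with a range from 8 ug/mL to 60 ug/mL.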

Compound 3, half-maximal inhibitory concentration: > 10 ug/mL
Compound 3: a limit, no number; the forecaster's own chance of this, stated with the estimate: 80%; the middle value lies beyond the limit too.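

In this assay compound 3 gives > 10 ug/mL as a limit of the assay and not a number. Within the data shown here, no step among compound 1, compound 2 and compound 3 can therefore be read. The compounds shown leave open where any of the three stands in this assay and whether the group on the carbonyl carbon matters there, the only evidence being this: the limit of > 10 ug/mL in this assay, at which 3 of the 3 values shown sit.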